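A few compounds are considered here, and "the series" means these few. Any claim that something is new, unique, unknown or untested is made for them only; others in the source may bear on it.

Compound 3 `O=C(Nc1cccc(-c2oc3cc(-c4ccc(F)cc4)ccc3c(=O)c2O)c1)c1cc(F)cc(F)c1` gives 2490 nM in a functional assay on MCF7 cells (Homo sapiens) for antiproliferative activity, read by CCK-8 assay, with a stated time of 72 h (on this read-out higher numbers stand for weaker inhibition and lower numbers for stronger inhibition), the second highest of the three numbers. Its nearest neighbour is compound 1 `Cc1ccc(C(=O)Nc2cccc(-c3oc4cc(-c5ccc(F)cc5)ccc4c(=O)c3O)c2)cc1`, with 2400 nM, so a 1.0-fold higher number from compound 1 to compound 3 (0.02 log units; within the scatter); the furthest is compound 2 `O=C(Nc1cccc(-c2oc3cc(-c4ccc(F)cc4)ccc3c(=O)c2O)c1)c1cccc(F)c1`, with 5770 nM, and a 2.3-fold lower number from compound 2 to compound 3 (0.36 log units; beyond the scatter). Compound 4 `O=C(Nc1cccc(-c2oc3cc(-c4ccc(F)cc4)ccc3c(=O)c2O)c1)c1ccc(-c2ccccc2)cc1` carries 4-phenylphenyl in place of 3,5-difluorophenyl on a carbonyl carbon. Two earlier steps also swap the ring on the carbonyl carbon: a 2.4-fold higher number from compound 1 to compound 2 (0.38 log units; beyond the scatter), and a 1.0-fold higher number from compound 1 to compound 3 (0.02 log units; within the scatter). Such swaps have so far moved the number only modestly or not beyond the scatter, so a similar outcome is expected here, with a larger entering group adding uncertainty. Compound 4 is therefore expected to give about 3200 nM, between 1200 nM and 9000 nM, meaning an expected 1.3-fold higher number from compound 3 to compound 4 (0.11 log units; within the scatter).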

Compound 4, half-maximal inhibitory concentration: 38500 nM
Compound 4: the middle estimate sits 12-fold (1.08 log units) below what was measured; measured number above the stated range.
By their numbers in this assay, from the lowest: compounds 1 and 3 (each within the scatter of the next); then compound 2; then compound 4.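

On the carbonyl carbon, the earlier ring swaps changed little, but 4-phenylphenyl sharply weakens inhibition in this assay with a 15-fold higher number from compound 3 to compound 4 (1.19 log units; beyond the scatter) and with a 6.7-fold higher number from compound 2 to compound 4 (0.82 log units; beyond the scatter) as well. Even the single edit of phenyl in place of methyl on an aromatic carbon gives a 16-fold higher number from compound 1 to compound 4 (1.21 log units; beyond the scatter) and shows that this position does not accept every aromatic group alike. Nothing available explains this loss. From the compounds shown here alone, whether a cyclohexyl or pyridine ring on the carbonyl carbon would keep the activity of compound 1 remains open.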